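This account rests on a few compounds, and the source may have more. Where it says the series, first, only, none or still open, it means among the compounds named here.

Measured so far in an ADME assay on PC-3 cells (Homo sapiens) for cytotoxicity, read by WST assay, tested at 100 uM; a lower number here means less inhibition, a higher number more inhibition at the concentration tested (going by the name of the read-out):
- compound 1, `O=C(Nc1ccc(Cl)cc1)C1CCCN(C(=O)c2cccc(-c3cccs3)c2)C1`: 4%
- compound 2, `O=C(Nc1cccc(Oc2ccccc2)c1)C1CCCN(C(=O)c2cccc(-c3ccco3)c2)C1`: 0%
- compound 3, `CC(C)(C)OC(=O)c1cccc(NC(=O)C2CCCN(C(=O)c3cc(C(F)(F)F)cc(C(F)(F)F)c3)C2)c1`: 0%

Compound 1 holds the largest of the three numbers, but its gaps to compound 2 and to compound 3 are both within the usual scatter of this assay, so the three compounds cannot be told apart on what is measured. Among the measured compounds shown here, all three sit near the bottom of the scale, and no step between two measured compounds that differ in one place is available, so there is no measured reference for how a single change moves the read-out.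

Compound 4, `O=C(Nc1ccc(Cl)cc1)C1CCCN(C(=O)c2cccc(-c3cnco3)c2)C1`, follows from compound 1 by one change: 1,3-oxazol-5-yl in place of thiophen-2-yl on an aromatic carbon. The ring that leaves and the ring that enters are both five-membered aromatic rings of five heavy atoms; the one entering carries two hetero atoms and two hydrogen-bond acceptors in place of one of each, with no donor and no charge on either side.

With compound 1, compound 2 and compound 3 all reading low and indistinguishable within the scatter, no step beyond the scatter is expected for this change. Compound 4 is estimated at 3%, with a range of -6% to 14%. The step from compound 1 to compound 4 that this estimate means is a number 1 percentage points lower from compound 1 to compound 4 (within the scatter), expected to lie within the scatter.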

Compound 4, a percentage reported as inhibition, at one concentration (the size of the read-out at that concentration, not a potency): 0%
Compound 4: the middle estimate sits 3 percentage points above what was measured; measured number inside the range.
By their numbers in this assay, from the lowest: compounds 2, 3, 4 and 1 (each within the scatter of the next).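

In this assay, among the compounds shown here, 1,3-oxazol-5-yl in place of thiophen-2-yl on the aromatic carbon gives a number 4 percentage points lower from compound 1 to compound 4 (within the scatter), the only step that can be read so far. At this place, meta to a large group, one five-membered aromatic ring with 1 hetero atom and one with 2 hetero atoms therefore cannot be told apart, although the entering ring carries the additional hydrogen-bond acceptor. For the compounds shown here, both compounds lie near the bottom of the scale, so this step shows only that the exchange leaves the read-out low at the concentration tested, and nothing on hand accounts for that result.

From the compounds shown here alone, whether any group at this place can lift the read-out clear of the scatter remains open, for example an aminomethyl group, a carboxylic acid or a longer alkyl chain in place of the five-membered ring. Also open, going by these compounds, is whether the same exchange gives a comparable step when the chlorophenyl amide of compound 1 is replaced by another aryl amide.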